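The source may hold more compounds than are shown below. What is called first, only, known or untested is meant among the compounds shown, and "the series" means these compounds.

Compound 1 `Cc1ccc(Cn2cc(COc3ccc4c(=O)ccoc4c3)nn2)cc1` gives 68500 nM in a functional assay on QGY7701 cells (Homo sapiens) for cytotoxicity, read by MTT assay, with a stated time of 48 h; on this read-out higher numbers stand for weaker inhibition and lower numbers for stronger inhibition; among the plain numbers it stands highest, with compound 3 `O=c1ccoc2cc(OCc3cn(Cc4cccc([N+](=O)[O-])c4)nn3)ccc12` at 14100 nM nearest. Compound 2 `Cc1ccccc1Cn1cc(COc2ccc3c(=O)ccoc3c2)nn1` returns only a limit, > 100000 nM. The change to compound 4 `O=c1ccoc2cc(OCc3cn(Cc4ccc([N+](=O)[O-])cc4)nn3)ccc12` is nitro in place of methyl on an aromatic carbon. The measured step that bears on it is a 4.9-fold lower number from compound 1 to compound 3 (0.69 log units; beyond the scatter), which likewise exchanges a methylphenyl for a nitrophenyl on a saturated chain carbon bound to an aromatic nitrogen, though as 3-nitrophenyl rather than 4-nitrophenyl. A step in the same direction, somewhat smaller, is therefore expected in this assay. Compound 4 is estimated at 20000 nM, range 7000 nM to 60000 nM, a step of a 3.4-fold lower number from compound 1 to compound 4 (0.53 log units; beyond the scatter).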

Compound 4, half-maximal inhibitory concentration: > 100000 nM
Compound 4: only a limit was reported; the forecaster's own chance of this, stated with the estimate: 5%; at least 5.0-fold (0.69 log units) between middle value and limit.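

In this assay the result for compound 4 is a limit, not a number: the limit of > 100000 nM in this assay, at which 2 of the 4 values shown sit. Exchanging 4-methylphenyl for 4-nitrophenyl gives no readable change (an at least 1.4-fold higher number from compound 1 to compound 4 (0.16 log units; that floor lies within the scatter)), whereas 4-nitrophenyl in place of 3-nitrophenyl gives a step beyond the scatter (an at least 7.0-fold higher number from compound 3 to compound 4 (0.85 log units; beyond the scatter)), so within these compounds the lower number of compound 3 goes with 3-nitrophenyl and not with a nitro group as such. The step between compound 2 and compound 4 cannot be read, as both are limits.

On these data alone, how far compound 4 lies past its limit stays open. Also open, as far as these compounds go, is whether an amine in place of the nitro group of compound 3 would keep its lower number.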